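The source may report more compounds than this note shows. Statements on the series, on what has been measured and on what is new or still open speak of the compounds shown alone.

Compound 1 `CC1(c2ccccc2)CC(S(=O)(=O)c2ccc(F)cc2)=C(c2ccc(/C(N)=N\O)cc2)O1` gives 29700 nM in an ADME assay on J774.A1 cells (Mus musculus) for cytotoxicity, read by MTT assay, with a stated time of 72 h; on this read-out lower numbers stand for higher toxicity in this test and higher numbers for lower toxicity in this test. Among the compounds with values here, compound 2 `CC1(c2ccc(-c3cccc(/C(N)=N\O)c3)cc2)CC(S(=O)(=O)c2ccc(F)cc2)=C(c2ccc(/C(N)=N\O)cc2)O1` gives 11000 nM in this assay, the lowest of the two numbers so far, with compound 1 as its only neighbour by a 2.7-fold lower number from compound 1 to compound 2 (0.43 log units; beyond the scatter). Compound 3 `Cc1ccc(-c2ccc(C3(C)CC(S(=O)(=O)c4ccc(F)cc4)=C(c4ccc(/C(N)=N\O)cc4)O3)cc2)cc1` differs from compound 2 by a group of 7 heavy atoms (7 carbon; one six-membered aromatic ring of carbon only) in place of a group of 10 heavy atoms (7 carbon, 2 nitrogen, 1 oxygen; one six-membered aromatic ring of carbon only), on an aromatic carbon. Within the data shown here, the single measured step, a 2.7-fold lower number from compound 1 to compound 2 (0.43 log units; beyond the scatter), bears on this only in part: it introduced the group that now leaves, and the change to compound 3 removes that group while an aromatic ring remains in its place. The expected step is therefore a 1.4-fold lower number from compound 2 to compound 3 (0.14 log units; within the scatter), small or none beyond the scatter. Compound 3 is estimated at 8000 nM, with a range from 3000 nM to 25000 nM.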

Compound 3, half-maximal cytotoxic concentration: 7910 nM
Estimate against measurement, compound 3: 1.0-fold (0.00 log units) above, and the stated range covers the measured number.
By their numbers in this assay, from the lowest: compounds 3 and 2 (each within the scatter of the next); then compound 1.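

In this assay, 4-methylphenyl in place of the larger group gives a 1.4-fold lower number from compound 2 to compound 3 (0.14 log units; within the scatter), so losing that group's hydrogen-bond donors and acceptors makes no difference beyond the scatter at this position. Against hydrogen on the same aromatic carbon, 4-methylphenyl gives a 3.8-fold lower number from compound 1 to compound 3 (0.57 log units; beyond the scatter), so a carbon-only aromatic ring is enough for the lower number. Nothing available explains this shift. From the compounds shown here alone, whether a non-aromatic group on this carbon, such as a carboxylic acid, an amine or a short alkyl chain, also lowers the number remains open.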